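This account rests on a few compounds, and the source may have more. Where it says the series, first, only, none or still open, it means among the compounds named here.

All three measured compounds were tested in a functional assay on MCF7 cells (Homo sapiens) for inhibition, read by sulforhodamine B assay, with a stated time of 24 h; on this read-out higher numbers stand for weaker inhibition and lower numbers for stronger inhibition:

Compound 1 `N#Cc1c(-c2ccccc2)cn(-c2ccc(S(=O)(=O)Nc3ccccn3)cc2)c1N`: 4600 nM
Compound 2 `N#Cc1c(-c2ccccc2)cn(-c2ccc(S(=O)(=O)Nc3ccccn3)cc2)c1NC(=O)CCC(=O)O`: 8320 nM
Compound 3 `N#Cc1c(-c2ccccc2)cn(-c2ccc(S(=O)(=O)Nc3nccs3)cc2)c1N1C(=O)CCC1=O`: 6710 nM

Compound 3 stands second highest of the three numbers. Its nearest neighbour is compound 2 and its furthest is compound 1, and both gaps lie within the scatter, so none of the three can be called stronger or weaker than another.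

Compound 4 `N#Cc1c(-c2ccccc2)cn(-c2ccc(S(=O)(=O)Nc3ccccn3)cc2)c1N1C(=O)CCC1=O` has not yet been measured. It differs from compound 3 in one place: pyridin-2-yl in place of 1,3-thiazol-2-yl on a sulfonamide nitrogen. For the measured compounds named here, no measured step concerns this exchange. Going by the values given here, the only step available, a 1.8-fold higher number from compound 1 to compound 2 (0.26 log units; within the scatter), concerns a different place on the core and stayed within the scatter. Compound 1 and compound 2, which already carry the pyridin-2-yl group that enters here, gave numbers close to that of compound 3, with the other side of the core differing as well. On this slim basis the expected step of a 1.1-fold lower number from compound 3 to compound 4 (0.05 log units; within the scatter) is none beyond the scatter. Compound 4 is therefore estimated at 6000 nM, with a range from 2500 nM to 15000 nM.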

Compound 4, half-maximal inhibitory concentration: 9930 nM
The estimate for compound 4 lay 1.7-fold (0.22 log units) below the measured number; the range from low to high includes it.
By their numbers in this assay, from the lowest: compounds 1, 3, 2 and 4 (each within the scatter of the next, the first and the last beyond it).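

In this assay, for the compounds shown here, the first change at the sulfonamide nitrogen, pyridin-2-yl in place of 1,3-thiazol-2-yl, gives a 1.5-fold higher number from compound 3 to compound 4 (0.17 log units; within the scatter) and so shows no clear effect of exchanging a five-membered aromatic ring for a six-membered one. Compound 4 also shows how 2,5-dioxopyrrolidin-1-yl compares with the two other groups at the far side of the core: in place of ((2-carboxyethyl)carbonyl)amino it gives a 1.2-fold higher number from compound 2 to compound 4 (0.08 log units; within the scatter) and no clear difference, while in place of amino it gives a 2.2-fold higher number from compound 1 to compound 4 (0.33 log units; beyond the scatter) as the only, and modest, step past the scatter. Nothing available explains these steps.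

On these data alone, whether a pyrimidin-2-yl ring or a plain methyl group on the sulfonamide nitrogen would move the number further remains open. So does whether the thiazole-to-pyridine exchange would read the same on a core carrying amino.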